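This account rests on a few compounds, and the source may have more. Where it says the series, first, only, none or still open, it means among the compounds named here.

Measured in a functional assay on I10 cells (Mus musculus) for inhibition, read by MTT assay, with a stated time of 72 h; on this read-out higher numbers stand for weaker inhibition and lower numbers for stronger inhibition:
- Compound 1 `C=CCc1ccc(OCc2c(Cl)cccc2Cl)c(-c2ccc(OCc3c(Cl)cccc3Cl)c(CC=C)c2)c1`: > 50000 nM, a limit
- Compound 2 `C=CCc1ccc(OCc2ccc(Cl)cc2Cl)c(-c2ccc(OCc3ccc(Cl)cc3Cl)c(CC=C)c2)c1`: > 50000 nM, a limit

Compound 2 therefore has no exact number, only a limit, and the same holds for compound 1: the limit of > 50000 nM in this assay, at which 2 of the 2 values shown sit. Compound 3 `C=CCc1ccc(OCc2ccc(Cl)cc2Cl)c(-c2ccc(O)c(CC=C)c2)c1` differs from compound 2 in one place, with hydrogen in place of 2,4-dichlorobenzyl on an oxygen on an aromatic ring. Among the compounds with values here, no measured pair shows the effect of this change, so a moderate move toward stronger inhibition in this assay is only an expectation. The expected change is an at least 2.5-fold lower number from compound 2 to compound 3 (0.39 log units; beyond the scatter). For compound 3, the estimated value is 20000 nM, with an expected range of 6000 nM to 50000 nM.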

Compound 3, half-maximal inhibitory concentration: 21100 nM
The estimate for compound 3 lay 1.1-fold (0.02 log units) below the measured number; low and high end bracket the measured number.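

In this assay, hydrogen in place of 2,4-dichlorobenzyl on this oxygen on an aromatic ring yields the first exact number shown, with an at least 2.3-fold lower number from compound 2 to compound 3 (0.37 log units; beyond the scatter). This change therefore moves the read-out toward stronger inhibition, by more than the scatter. Its full size cannot be read, as compound 2 carries only a limit: the limit of > 50000 nM in this assay, at which 2 of the 3 values shown sit.

The compounds shown leave open how a methyl or a carboxymethyl group on this oxygen would compare with hydrogen. They also leave open what hydrogen would do in place of the remaining 2,4-dichlorobenzyl group.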